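The source may report more compounds than this note shows. Statements on the series, on what has been measured and on what is new or still open speak of the compounds shown alone.

Measured so far in an assay on HEK293 cells for displacement of a labelled ligand from Orexin receptor type 2 (Homo sapiens), read by scintillation counting, with a stated time of 90 min; on this read-out higher numbers stand for weaker inhibition and lower numbers for stronger inhibition:
- compound 1, `COc1cc(F)c(CN2C(=O)N(c3ccc(OC)c(OC)c3)S(=O)(=O)c3ccccc32)c(F)c1`, gives 0.501 nM
- compound 2, `COc1ccc(N2C(=O)N(Cc3ccccc3F)c3ccccc3S2(=O)=O)cc1OC`, gives 6.31 nM

Compound 1 holds the lowest of the two numbers in this assay; its nearest neighbour is compound 2, and the step of a 13-fold higher number from compound 1 to compound 2 (1.10 log units; beyond the scatter). That step changes the benzyl group on the ring nitrogen of the shared core and is therefore not the change followed here.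

Compound 3, `COc1cc(F)c(CN2C(=O)N(c3ccc(OC)c(OC)n3)S(=O)(=O)c3ccccc32)c(F)c1`, differs from compound 1 in one place: 5,6-dimethoxypyridin-2-yl in place of 3,4-dimethoxyphenyl on an amide-type nitrogen in a ring. For the measured compounds named here, no measured step touches this aryl group on the amide-type nitrogen, so the two known compounds give no direct guide to its size or direction. In the absence of such a step, the expectation is that compound 3 stays close to compound 1 in this assay, with a step of a 2.0-fold higher number from compound 1 to compound 3 (0.30 log units; within the scatter) expected to lie within or only a little beyond the scatter. Compound 3 is therefore estimated at 1 nM in this assay, with a range from 0.3 nM to 4 nM.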

Compound 3, inhibition constant: 0.2 nM
The estimate for compound 3 lay 5.0-fold (0.70 log units) above the measured number; the measured number lies below the stated range.
By their numbers in this assay, from the lowest: compound 3; then compound 1; then compound 2.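

For the compounds shown here, until now, no measured step touched the aryl group on the amide-type nitrogen, so nothing showed whether this position responds to change. In this assay, putting 5,6-dimethoxypyridin-2-yl in place of 3,4-dimethoxyphenyl gives a 2.5-fold lower number from compound 1 to compound 3 (0.40 log units; beyond the scatter), a modest shift towards stronger inhibition that lies beyond the usual scatter, so this position does respond, even to a small edit. The two groups hold the same number of heavy atoms and both carry two methoxy groups, yet the entering group has a ring nitrogen and its count of hydrogen-bond acceptors rises from 2 to 3; no measurement here says why the number falls.

A single swap cannot show whether the ring nitrogen alone accounts for the shift, or whether the same change would lower the number when the 2-fluorobenzyl group of compound 2 sits on the shared core. It also leaves open how far the position tolerates larger edits, such as ethoxy groups in place of the two methoxy groups, or an amine on the aromatic ring.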